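Adding a second chloro to compound 2

The compounds below may be only part of what the source reports. "The series", "measured", "known", "first", "only" and "open" are said of these compounds alone.

Values so far in a functional assay on MC-38 cells (Mus musculus) for antiproliferative activity, read by colorimetric assay and MTT assay (a higher number here means a weaker inhibitor, a lower number a stronger inhibitor), are:
compound 1 `N#Cc1ccc(S(=O)(=O)Nc2cccc3c(Cl)c[nH]c23)cc1` gives 0.13 ug/mL
compound 2 `N#Cc1ccc(S(=O)(=O)Nc2ccc(Cl)c3cc[nH]c23)cc1` gives 0.22 ug/mL

Compound 2 stands at 0.22 ug/mL and compound 1 at 0.13 ug/mL on this scale, the two within the usual scatter of each other. Compound 3 `N#Cc1ccc(S(=O)(=O)Nc2ccc(Cl)c3c(Cl)c[nH]c23)cc1` takes compound 2 and puts chloro in place of hydrogen on an aromatic carbon of the five-membered ring, two ring bonds from the ring nitrogen (chloro in place of hydrogen on an aromatic carbon). Among the compounds with values here, no measured step isolates this change. Compound 1 already carries chloro on that carbon, and its value of 0.13 ug/mL gives no sign of a large shift. A small move towards a lower number in this assay is therefore expected, possibly none beyond the scatter. The expected step is a 1.8-fold lower number from compound 2 to compound 3 (0.26 log units; within the scatter) in size. The estimate for compound 3 is 0.12 ug/mL with 0.04 ug/mL and 0.35 ug/mL as its expected ends.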

Compound 3, half-maximal inhibitory concentration: 0.12 ug/mL
For compound 3 middle estimate and measured number coincide at the digits printed; low and high end bracket the measured number.
By their numbers in this assay, from the lowest: compounds 3, 1 and 2 (each within the scatter of the next).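

In this assay, chloro in place of hydrogen on an aromatic carbon of the five-membered ring, two ring bonds from the ring nitrogen, gives a 1.8-fold lower number from compound 2 to compound 3 (0.26 log units; within the scatter) and so moves the value by no more than the scatter, even with a chloro already present elsewhere on the core. The other one-place pair gives a 1.1-fold lower number from compound 1 to compound 3 (0.03 log units; within the scatter) and is also within the scatter, so compound 3 with both chloro groups cannot be told apart from either compound with one chloro. Nothing measured here bears on the reason for these small steps.

As far as these compounds go, whether this carbon accepts groups other than chloro, such as an amine, a methoxy group or a carboxylic acid, remains open. Also open is how the core behaves with no chloro at all, as every compound shown carries at least one.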